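Nitro for methoxy on the growth-inhibition series

The source may report more compounds than this note shows. Statements on the series, on what has been measured and on what is new or still open speak of the compounds shown alone.

Compound 1 `COc1ccc(Cc2nnc(NC(=O)/C(C#N)=C/c3ccccc3OS(=O)(=O)c3ccc([N+](=O)[O-])cc3)s2)cc1`: 70%
Compound 2 `COc1ccc(S(=O)(=O)Oc2ccccc2/C=C(\C#N)C(=O)Nc2nnc(Cc3cccc(F)c3)s2)cc1`: 74%

In a functional assay on RS4-11 cells (Homo sapiens) for inhibition, read by CCK-8 assay, with a stated time of 48 h, tested at 20 uM (a lower number here means less inhibition of growth, a higher number more inhibition of growth at the concentration tested), compound 2 gives 74%, within the scatter of compound 1 at 70%. Compound 3 `N#C/C(=C\c1ccccc1OS(=O)(=O)c1ccc([N+](=O)[O-])cc1)C(=O)Nc1nnc(Cc2cccc(F)c2)s1` carries one change relative to compound 2: nitro in place of methoxy on an aromatic carbon. This places nitro in place of methoxy on an aromatic carbon, para to a large group. Among the measured compounds shown here, no measured step isolates this change, so no shift beyond the scatter is expected, and no direction is favoured. The expected step is a number 2 percentage points lower from compound 2 to compound 3 (within the scatter). The estimate for compound 3 is 72%, with an expected range from 58% to 85%.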

Compound 3, percent growth inhibition at one concentration: 65%
The estimate for compound 3 lay 7 percentage points above the measured number, within the range that was stated.
By their numbers in this assay, from the lowest: compounds 3, 1 and 2 (each within the scatter of the next).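

In this assay, nitro in place of methoxy on an aromatic carbon, para to a large group, gives a number 9 percentage points lower from compound 2 to compound 3 (within the scatter) and so leaves growth inhibition unchanged within the scatter at this position. With nitro held in place, 3-fluorophenyl in place of 4-methoxyphenyl gives a number 5 percentage points lower from compound 1 to compound 3 (within the scatter) and likewise stays within the scatter. Nothing at hand offers a reason for either step.

As far as these compounds go, whether an amine or a carboxylic acid on this aromatic carbon would move growth inhibition beyond the scatter remains open.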